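A few compounds are considered here, and "the series" means these few. Any claim that something is new, unique, unknown or untested is made for them only; others in the source may bear on it.

Among the measured compounds shown here, in a functional assay on MCF7 cells (Homo sapiens) for inhibition, read by MTT assay, with a stated time of 72 h (a higher number here means a weaker inhibitor, a lower number a stronger inhibitor), compound 1 `CO[C@@H]1[C@H]2OC(=O)C[C@H]2O[C@@H]1[C@H](O)c1ccccc1` gives 4040 nM, the only numerical value in this set. Compound 2 `CO[C@H](c1ccccc1)[C@H]1O[C@@H]2CC(=O)O[C@@H]2[C@H]1O` gives > 100000 nM, which is a limit of the assay. Compound 3 `CO[C@@H]1[C@H]2OC(=O)C[C@H]2O[C@@H]1[C@@H](OC)c1ccccc1` gives > 100000 nM, which is also a limit. Compound 3 therefore has no numerical position in this assay, and the limit of > 100000 nM in this assay, at which 2 of the 3 values shown sit, describes the set so far.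

Compound 4 `CO[C@@H]1[C@H]2OC(=O)C[C@H]2O[C@@H]1[C@H](OC)c1ccccc1` is the stereoisomer of compound 3: the two compounds have the same atoms and bonds and differ only in configuration as drawn: 1 of 5 stereo elements differ; a stereocentre at a saturated chain carbon is drawn S in compound 3 and R in compound 4. A stereocentre at a saturated chain carbon is drawn S in compound 3 and R in compound 4. For the measured compounds named here, no measured step isolates this change, so its size in this assay is poorly constrained. Going by the values given here, compound 1 at 4040 nM shows only that a numerical reading is possible within this small set. A shift toward stronger inhibition is expected, although another limit remains quite possible. The estimated change is an at least 2.5-fold lower number from compound 3 to compound 4 (0.39 log units; beyond the scatter). The expected value for compound 4 is 40000 nM, with an estimated range from 5000 nM to 150000 nM.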

Compound 4, half-maximal inhibitory concentration: > 100000 nM
Compound 4 ended at the assay's limit; the forecaster's own chance of this, stated with the estimate: 45%; middle value at least 2.5-fold (0.39 log units) away from the limit.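

In this assay, among the compounds shown here, methyl in place of hydrogen on an oxygen on a saturated carbon gives an at least 24-fold higher number from compound 1 to compound 4 (1.39 log units; beyond the scatter), so the only numerical reading in the set is lost with this change. The steps to compound 4 from compound 2 and from compound 3 cannot be read, as each joins two limits. Changing the drawn configuration at the saturated chain carbon with the methyl in place still brings no numerical reading, so neither configuration of that methylated compound gives a number here, and the size of any effect stays unknown: the fact that compounds 3 and 4 differ only in the configuration as drawn

Still open, going by these compounds, is whether an ethyl ether, an acetate ester or an amine in place of the hydroxyl of compound 1 keeps a numerical reading. Also open, on these data alone, is what the same change of configuration does with that hydroxyl kept.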